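Cyano for fluoro on the fused ring of compound 1

This account rests on a few compounds, and the source may have more. Where it says the series, first, only, none or still open, it means among the compounds named here.

Compound 1 `O=C(O)CC(Cc1nc2cc(F)ccc2[nH]1)c1ccc(Cl)cc1` gives 30% in an assay on isolated protein for inhibition of protein kinase C zeta type (Homo sapiens), read by 33P incorporation, tested at 200 uM (a lower number here means a weaker effect, a higher number a stronger effect of the compound at the concentration tested), the higher of the two numbers in hand; the nearest is compound 2 `O=C(O)CC(Cc1nc2cc(C(=O)O)ccc2[nH]1)c1ccc(Cl)cc1`, which gives 0% in this assay. Among the compounds with values here, the one measured step, a number 30 percentage points lower from compound 1 to compound 2 (beyond the scatter), replaces fluoro with carboxy on an aromatic carbon of the shared core. Compound 3 `N#Cc1ccc2[nH]c(CC(CC(=O)O)c3ccc(Cl)cc3)nc2c1` is to be measured in this assay; it differs from compound 1 by cyano in place of fluoro on an aromatic carbon. The carboxy step is the only one that bears on this change, and it brought the number down beyond the scatter. Cyano is not carboxy, so that step is a loose guide only, and some loss from compound 1 is expected, but a smaller one. In this assay compound 3 is therefore expected to give 20%, between 5% and 40%. The expected step of a number 10 percentage points lower from compound 1 to compound 3 (within the scatter) would be a modest drop.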

Compound 3, a percentage reported as inhibition, at one concentration (the size of the read-out at that concentration, not a potency): 0%
Compound 3: middle estimate off by 20 percentage points, on the high side; measured number outside the range, below it.
By their numbers in this assay, from the lowest: compounds 2 and 3 (each within the scatter of the next); then compound 1.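

In this assay, cyano in place of fluoro gives a number 30 percentage points lower from compound 1 to compound 3 (beyond the scatter), so the loss seen with carboxy at this aromatic carbon is not confined to that one group. Between the two replacements the data show no change at the digits printed from compound 2 to compound 3 (within the scatter), which leaves compound 1, with its fluoro, as the only one of the three set apart beyond the scatter. Nothing measured here explains why either replacement lowers the number.

Open, on these data alone, is whether the fluoro itself matters or any other group would also lower the number, a question that hydrogen, chloro, methyl, methoxy or an amine on this carbon would address. As far as these compounds go, each read-out is a percentage at one concentration, so the potency of compound 1 also stays open.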